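The compounds below may be only part of what the source reports. "The series", "measured", "known", "first", "only" and "open" are said of these compounds alone.

Compound 3 `COc1cc(N(Cc2nc3ccccc3[nH]2)C(=O)c2ccc(F)cc2)cc(OC)c1OC` carries a (4-fluorophenyl)carbonyl on the nitrogen of the shared core. Within the data shown here, in a functional assay on MCF7 cells (Homo sapiens) for inhibition, read by MTT assay, with a stated time of 48 h (on this read-out lower numbers stand for stronger inhibition and higher numbers for weaker inhibition), compound 3 gives 45200 nM, the highest of the three numbers measured so far: compound 1 `COc1cc(N(Cc2nc3ccccc3[nH]2)S(=O)(=O)c2ccc(Br)cc2)cc(OC)c1OC` gives 7740 nM and compound 2 `COc1cc(N(Cc2nc3ccccc3[nH]2)S(=O)(=O)c2ccccc2Cl)cc(OC)c1OC` gives 38100 nM. Compound 4 `COc1cc(N(Cc2nc3ccccc3[nH]2)C(=O)c2cccc(Cl)c2)cc(OC)c1OC` differs from compound 3 by 3-chlorophenyl in place of 4-fluorophenyl on a carbonyl carbon. Among the measured compounds shown here, no measured step exchanges one halogenated phenyl for another on a carbonyl carbon; the nearest, a 4.9-fold higher number from compound 1 to compound 2 (0.69 log units; beyond the scatter), does so on a sulfonyl sulfur, while a 5.8-fold higher number from compound 1 to compound 3 (0.77 log units; beyond the scatter) and a 1.2-fold higher number from compound 2 to compound 3 (0.07 log units; within the scatter) change the linker itself. The expectation for compound 4 is therefore a step of a 1.1-fold lower number from compound 3 to compound 4 (0.05 log units; within the scatter), not clearly beyond the scatter. Compound 4 is estimated at 40000 nM, with a range from 12000 nM to 130000 nM.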

Compound 4, half-maximal inhibitory concentration: 34900 nM
Compound 4: middle estimate off by 1.1-fold (0.06 log units), on the high side; measured number inside the range.
By their numbers in this assay, from the lowest: compound 1; then compounds 4, 2 and 3 (each within the scatter of the next).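

In this assay, among these compounds, the first exchange of one halogenated phenyl for another on a carbonyl carbon gives a 1.3-fold lower number from compound 3 to compound 4 (0.11 log units; within the scatter) and so shows that 3-chlorophenyl and 4-fluorophenyl cannot be told apart here. The carbonyl compound 4 also stays level with the sulfonyl compound 2, with a 1.1-fold lower number from compound 2 to compound 4 (0.04 log units; within the scatter) as the printed step, while a 4.5-fold higher number from compound 1 to compound 4 (0.65 log units; beyond the scatter) keeps compound 1 apart from the others. Nothing measured here explains these numbers. As far as these compounds go, it remains open whether 4-bromophenyl on the carbonyl carbon would match compound 1, and whether a phenyl carrying an amine or a carboxylic acid would move the number beyond the scatter.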